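Cytotoxicity notes on the amide-substituent series

This account rests on a few compounds, and the source may have more. Where it says the series, first, only, none or still open, it means among the compounds named here.

Compound 1 `Cc1cc(C#N)cc(C)c1Oc1nc(Nc2ccc(C#N)cc2)ncc1/C=C/C(=O)NC1CC1` and compound 2 `Cc1cc(C#N)cc(C)c1Oc1nc(Nc2ccc(C#N)cc2)ncc1/C=C/C(=O)NC1CCN(S(C)(=O)=O)CC1` share one core and differ only in the group on the amide-type nitrogen. In an ADME assay on TZM cells (Homo sapiens) for cytotoxicity, with a stated time of 1 days (on this read-out higher numbers stand for lower toxicity in this test and lower numbers for higher toxicity in this test), compound 1 gives a limit of > 221 nM rather than a number. Compound 2 gives a limit of > 175 nM in this assay, likewise not a number. The step that the two limits leave unreadable from compound 1 to compound 2 is therefore unreadable, the two values sitting at the limit of > 221 nM in this assay, at which 1 of the 2 values shown sits, and (the limit of > 175 nM in this assay, at which 1 of the 2 values shown sits). Compound 3 `Cc1cc(C#N)cc(C)c1Oc1nc(Nc2ccc(C#N)cc2)ncc1/C=C/C(=O)N1CCN(S(C)(=O)=O)CC1` carries the change (4-(methylsulfonyl)piperazin-1-yl in place of (1-(methylsulfonyl)piperidin-4-yl)amino on a carbonyl carbon). Going by the values given here, no measured step bears directly on this change, and the single measured step has no readable size, so no direction beyond the scatter can be expected for compound 3. The expected step is a step that the limit leaves unreadable from compound 2 to compound 3. For compound 3 the estimate in this assay is 300 nM, with a range from 150 nM to 1000 nM, and a limit rather than a number is expected to be the likely outcome.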

Compound 3, half-maximal cytotoxic concentration: > 179 nM
Compound 3 gave a limit, no number; the forecaster's own chance of this, stated with the estimate: 80%; the middle value does not contradict the limit.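

In this assay compound 3 gives > 179 nM, a limit and not a number. Going by these compounds alone, compound 1, compound 2 and compound 3 all stand as limits, and no step among them can be read. The compounds shown leave open whether changing the amide-type nitrogen substituent shifts cytotoxicity at all.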